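The source may report more compounds than this note shows. Statements on the series, on what has been measured and on what is new or still open speak of the compounds shown alone.

Compound 1 `O=C1/C(=C\c2cccc(Oc3ccccc3)c2)c2ccccc2N1c1c(Cl)cccc1Cl` gives 24 ug/mL in a functional assay on L132 cells (Homo sapiens) for cytotoxicity, read by MTT assay, with a stated time of 72 h; a higher number here means that more compound is needed for the effect, a lower number that less compound is needed. Compound 2 `O=C1/C(=C\c2cccc(Br)c2)c2ccccc2N1c1c(Cl)cccc1Cl` gives 19 ug/mL in this assay. Compound 3 `COc1ccc(/C=C2\C(=O)N(c3c(Cl)cccc3Cl)c3ccccc32)cc1OC` reaches only the limit > 100 ug/mL in this assay.

Compound 2 has the lowest of the two numbers, but its nearest neighbour, compound 1, lies within the scatter: a 1.3-fold lower number from compound 1 to compound 2 (0.10 log units; within the scatter). Compound 4 `O=C1/C(=C\c2c(Cl)cccc2Cl)c2ccccc2N1c1c(Cl)cccc1Cl` differs from compound 2 by 2,6-dichlorophenyl in place of 3-bromophenyl on a double-bonded chain carbon bound to a double-bonded ring carbon. Within the data shown here, the only measured step, a 1.3-fold lower number from compound 1 to compound 2 (0.10 log units; within the scatter), exchanges one group on this same ring for another and was small. The limit for compound 3 the limit of > 100 ug/mL in this assay, at which 1 of the 3 values shown sits, shows that changes on this ring can also push the number out of range. Compound 4 is therefore expected to give 22 ug/mL, with a range from 9 ug/mL to 60 ug/mL. The expected step is a 1.2-fold higher number from compound 2 to compound 4 (0.06 log units; within the scatter).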

Compound 4, concentration for half-maximal effect: > 100 ug/mL
Compound 4 was reported as a limit; the forecaster's own chance of this, stated with the estimate: 15%; at least 4.5-fold (0.65 log units) between middle value and limit.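

In this assay the exchange at this position gives an at least 5.2-fold higher number from compound 2 to compound 4 (0.72 log units; beyond the scatter) and so is the first single change on this ring shown to lie beyond the scatter. The aryl group here is thus not freely exchangeable, even though 2,6-dichlorophenyl and 3-bromophenyl both carry only halogens on the ring. Compound 4 is reported only as a limit, as is compound 3: the limit of > 100 ug/mL in this assay, at which 2 of the 4 values shown sit.

From the compounds shown here alone, whether a single chlorine on this ring would keep the number measurable remains open. So does what a phenyl ring bearing an amine or a carboxylic acid would give.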